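From Fluorophenyl-ethenyl to Methylphenyl: An Expected Shift

The source may hold more compounds than are shown below. What is called first, only, known or untested is meant among the compounds shown, and "the series" means these compounds.

Measured compounds:
- compound 1, `COC(=O)/C=C/c1cccc(N(Cc2ccc(/C=C/c3ccc(F)cc3)cc2)C(=O)C(C)C)c1`: 120 nM
- compound 2, `COC(=O)/C=C/c1cccc(N(Cc2ccc(/C=C/c3ccc(F)cc3)cc2)C(=O)NC(C)C)c1`: 348 nM
- compound 3, `COC(=O)/C=C/c1cccc(N(Cc2ccc(-c3cccc(OC)c3)cc2)C(=O)NC(C)C)c1`: 1370 nM

All three were tested in an assay on isolated protein with Bile acid receptor (Homo sapiens) as the target; on this read-out lower numbers stand for an effect already at smaller amounts and higher numbers for an effect only at larger amounts of compound. Among them compound 1 holds the lowest number: compound 2 lies nearest, with a 2.9-fold higher number from compound 1 to compound 2 (0.46 log units; beyond the scatter), while compound 3 lies furthest, its value being the highest of the three. Compound 4, `COC(=O)/C=C/c1cccc(N(Cc2ccc(-c3ccc(C)cc3)cc2)C(=O)C(C)C)c1`, has not yet been measured. It differs from compound 1 in one place: 4-methylphenyl in place of 2-(4-fluorophenyl)ethenyl on an aromatic carbon.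

Among the compounds with values here, only one measured step touches the same part of the molecule. Going from compound 2 to compound 3, the same 2-(4-fluorophenyl)ethenyl group was exchanged for a 3-methoxyphenyl group, and this gave a 3.9-fold higher number from compound 2 to compound 3 (0.60 log units; beyond the scatter). The group entering compound 4 is a different one, 4-methylphenyl rather than 3-methoxyphenyl, so that step is a guide rather than a template, and the rest of the molecule also differs, compound 2 carrying an isopropylamino group where compound 1 carries isopropyl.

On this basis a rise in this assay of modest size is expected, with a 2.9-fold higher number from compound 1 to compound 4 (0.46 log units; beyond the scatter). Compound 4 is therefore estimated at 350 nM, with a plausible range from 120 nM to 1100 nM.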

Compound 4, half-maximal effective concentration: 118 nM
Compound 4: the middle estimate sits 3.0-fold (0.47 log units) above what was measured; measured number outside the range, below it.
By their numbers in this assay, from the lowest: compounds 4 and 1 (each within the scatter of the next); then compound 2; then compound 3.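

In this assay, replacing 2-(4-fluorophenyl)ethenyl with 4-methylphenyl gives a 1.0-fold lower number from compound 1 to compound 4 (0.01 log units; within the scatter), so at this position on the core of compound 1, the double bond outside the aromatic rings and the fluorine can both go without a change beyond the scatter. Within the data shown here, the only earlier step at this position, a 3.9-fold higher number from compound 2 to compound 3 (0.60 log units; beyond the scatter), showed a rise with a different entering group on a different background, and the new step shows that such a rise does not follow from removing 2-(4-fluorophenyl)ethenyl alone. No measurement here explains why these two groups give numbers within the scatter of each other.

The two steps differ in both the entering group and the isopropyl or isopropylamino group on the carbonyl carbon, so the compounds shown cannot separate the influence of 4-methylphenyl from that of its surroundings. Going by these compounds, it also remains open whether a 4-fluorophenyl group, which keeps the fluorine without the double bond, or a 4-aminophenyl group, which places an amine on the ring, would fit this position equally well.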